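The source may hold more compounds than are shown below. What is called first, only, known or untested is meant among the compounds shown, and "the series" means these compounds.

Measured in a physicochemical assay for lipophilicity, in phosphate buffer, measured as octanol-water partition, at pH 11.5; on this read-out higher numbers stand for higher lipophilicity and lower numbers for lower lipophilicity:
compound 1 `CCCCCCCCNC(=N)NC(=N)Nc1ccc(C)cc1` gives 4.93
compound 2 `CSc1ccc(NC(=N)NC(=N)NCCCCCCNC(=N)NC(=N)Nc2ccc(SC)cc2)cc1` gives 4.58
compound 3 `CCCCC(CC)CNC(=N)NC(=N)Nc1ccc(C)cc1` gives 4.73

On these numbers, compound 1 and compound 3 cannot be told apart, and compound 2 lies below compound 1 by more than the usual scatter.

Compound 4 `CCCCCCCCNC(=N)NC(=N)Nc1ccc(C(F)(F)F)cc1` has not been measured yet. It keeps the core of compound 1 and differs in one place, with trifluoromethyl in place of methyl on an aromatic carbon of the ring.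

Going by the values given here, only one measured step is available, and it bears on this change only loosely. That step, a number 0.20 log units lower from compound 1 to compound 3 (within the scatter), alters the chain and leaves the ring untouched. Among the compounds with values here, no measured pair changes the ring group, so the expectation rests on the structural change alone and stays rough. A modest rise in this assay is expected, with a wide margin on either side.

The estimated change is a number 0.37 log units higher from compound 1 to compound 4 (beyond the scatter), a small upward step.

Compound 4 is expected at 5.3, with an estimated range from 4.9 to 5.7.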

Compound 4, partition coefficient: 5.31
Compound 4: middle estimate off by 0.01 log units, on the low side, and the stated range covers the measured number.
By their numbers in this assay, from the lowest: compounds 2, 3 and 1 (each within the scatter of the next, the first and the last beyond it); then compound 4.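

In this assay the ring position para to a large group now has a measured step of its own, since trifluoromethyl in place of methyl gives a number 0.38 log units higher from compound 1 to compound 4 (beyond the scatter) and this change lies beyond the scatter. Going by these compounds alone, the only earlier step, a number 0.20 log units lower from compound 1 to compound 3 (within the scatter), altered the chain, left the ring untouched and stayed within the scatter, so a change at this ring carbon is the one that moves the read-out clearly here. Nothing available explains the size of this step.

From the compounds shown here alone, what a chlorine atom, a methoxy group or a nitrile would do at this same ring carbon remains open. Also open, going by these compounds, is whether trifluoromethyl in place of methyl would give a similar step when the core carries the 1-ethylpentyl chain of compound 3.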